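Replacing a Sulfonamide with a Pyrazole on a Shared Core

The source may hold more compounds than are shown below. What is called first, only, known or untested is meant among the compounds shown, and "the series" means these compounds.

Of the compounds shown here, three built on one shared core have so far been tested in a functional assay on CHO cells for agonist activity at Alpha-1B adrenergic receptor (Homo sapiens), read by FLIPR and calcium flux; a lower number here means that less compound is needed, a higher number that more compound is needed for the effect. Compound 1 `CCCS(=O)(=O)Nc1cccc2c1CCC2c1ncc[nH]1` returns in this assay only a limit, > 10000 nM. Compound 2 `CS(=O)(=O)Nc1cccc2c1CCC2c1ncc[nH]1` also returns only a limit, > 10000 nM. Compound 3 `Cc1ccc2c(c1NS(C)(=O)=O)CCC2c1ncc[nH]1` likewise returns only a limit, > 10000 nM. The step that the two limits leave unreadable from compound 1 to compound 2 and the step that the two limits leave unreadable from compound 2 to compound 3 therefore cannot be sized, a situation summed up by the limit of > 10000 nM in this assay, at which 3 of the 3 values shown sit. Compound 2 thus stands at the limit together with its two neighbours, and nothing measured separates any of them.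

Compound 4 `c1cc(-c2cn[nH]c2)c2c(c1)C(c1ncc[nH]1)CC2` has not yet been measured. It differs from compound 2 in this way: 1H-pyrazol-4-yl in place of methanesulfonamido on an aromatic carbon. Neither measured step touches a change of this kind; the two unreadable steps varied only the chain on the sulfonyl sulfur and a methyl on the aromatic ring, so they offer no direction and no size for the move to compound 4. The estimated step of an at least 1.2-fold lower number from compound 2 to compound 4 (0.09 log units; that floor lies within the scatter) therefore carries wide bounds. Compound 4 is expected to give 8000 nM in this assay, with a range from 800 nM to 50000 nM.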

Compound 4, half-maximal effective concentration: > 10000 nM
Compound 4 was reported as a limit; the forecaster's own chance of this, stated with the estimate: 60%; middle value at least 1.2-fold (0.09 log units) away from the limit.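

In this assay compound 4 gives > 10000 nM as a limit of the assay. The steps to compound 4 from compound 1 and from compound 2 therefore cannot be read. From the compounds shown here alone, what stays open is whether 1H-pyrazol-4-yl in place of methanesulfonamido changes the amount of compound needed at all, and in which direction.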